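The source may report more compounds than this note shows. Statements on the series, on what has been measured and on what is new or still open speak of the compounds shown alone.

In a functional assay on HeLa cells (Homo sapiens) for antiproliferative activity, read by MTT assay, with a stated time of 72 h (a higher number here means a weaker inhibitor, a lower number a stronger inhibitor), compound 1 `COc1cc(-c2ncnn2-c2cccc(N)c2)cc(OC)c1OC` gives > 10000 nM, which is a limit of the assay and not a number. Compound 2 `COc1cc(-c2ncnn2-c2ccc(Cl)cc2)cc(OC)c1OC` gives > 10000 nM, and this too is only a limit. Compound 2 therefore has no exact position on the scale, and the whole record so far is the limit of > 10000 nM in this assay, at which 2 of the 2 values shown sit. Among the compounds with values here, the one measured step, a step that the two limits leave unreadable from compound 1 to compound 2, gives no size to carry forward.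

Compound 3 `COc1cc(-c2ncnn2-c2ccc(Cl)c(Cl)c2)cc(OC)c1OC` differs from compound 2 by chloro in place of hydrogen on an aromatic carbon, turning 4-chlorophenyl into 3,4-dichlorophenyl. The new chloro sits ortho to the existing chloro group and meta to a large group. With no readable step from compound 1 to compound 2, the data support no particular size or direction for this change in this assay. The expectation is therefore no shift beyond the scatter, and compound 3 may well be reported as a limit again. The expected step is a step that the limit leaves unreadable from compound 2 to compound 3. For compound 3 the estimated value is 12000 nM, with an expected range from 3000 nM to 40000 nM.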

Compound 3, half-maximal inhibitory concentration: > 10000 nM
Compound 3: only a limit was reported; the forecaster's own chance of this, stated with the estimate: 80%; the middle value is on the limit's open side.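

Compound 3 is reported only as a limit of the assay, as are compound 1 and compound 2, so no step among these three compounds can be read. The compounds shown leave open how far apart the three actually lie in this assay, and whether any change on the shared core would give an exact value.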